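The source may hold more compounds than are shown below. What is called first, only, known or untested is meant among the compounds shown, and "the series" means these compounds.

Of the compounds shown here, three that share a common core have been measured for binding in an assay on isolated protein (blood) for antagonist activity at C-C chemokine receptor type 4 (Homo sapiens), read by flow cytometry, with a stated time of 30 min; a higher number here means weaker binding, a lower number tighter binding. Compound 1 `CC(=O)NCc1cccc(Cn2nc(NS(=O)(=O)c3ccc(Cl)s3)c3c(F)cccc32)c1` gives 5010 nM. Going by the values given here, compound 2 `CC(=O)NCc1cccc(Cn2nc(NS(=O)(=O)c3ccc(Cl)s3)c3c(O)cccc32)c1` gives 794 nM, and the only single-point step in the set, a 6.3-fold lower number from compound 1 to compound 2 (0.80 log units; beyond the scatter), concerns a hydroxy in place of fluoro on an aromatic carbon of the core. Compound 3 `COc1cccc2c1c(NS(=O)(=O)c1ccc(Cl)s1)nn2Cc1cccc(CNC(=O)C2COC2)c1` gives 1000 nM, which places it second highest of the three numbers: compound 2 is its nearest neighbour, separated by a gap that lies within the scatter, while compound 1 is its furthest, separated by a gap that lies beyond the scatter.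

Compound 4 `COc1cccc2c1c(NS(=O)(=O)c1ccc(Cl)s1)nn2Cc1cccc(CNC(=O)C2CCOCC2)c1` differs from compound 3 at one place only: oxan-4-yl in place of oxetan-3-yl on a carbonyl carbon. Among the compounds with values here, no measured step bears directly on this change; the step from compound 1 to compound 2 alters the core itself, not the ring attached to the carbonyl carbon of the amide side chain. With nothing in the data pointing in either direction, the step expected here, no change at the digits printed from compound 3 to compound 4 (within the scatter), is one that stays within the scatter. Compound 4 is therefore estimated at 1000 nM in this assay, with a range from 400 nM to 2500 nM.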

Compound 4, dissociation constant: 501 nM
Compound 4: the middle estimate sits 2.0-fold (0.30 log units) above what was measured, within the range that was stated.
By their numbers in this assay, from the lowest: compounds 4, 2 and 3 (each within the scatter of the next); then compound 1.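

Exchanging oxetan-3-yl for oxan-4-yl on the carbonyl carbon gives a 2.0-fold lower number from compound 3 to compound 4 (0.30 log units; within the scatter) in this assay, so the two compounds cannot be told apart in this measurement. Going by these compounds alone, this is the first measured step at the ring on this carbonyl carbon, since the earlier step changed the core, and it shows that a six-membered ring with 6 heavy atoms can stand where a four-membered ring with 4 heavy atoms stood, with no difference beyond the scatter for this pair. Nothing available here offers an explanation for this result.

The compounds shown leave open how binding would respond to a cyclohexyl ring, with carbon in place of the ring oxygen, or to a piperidin-4-yl ring, with an amine nitrogen there, on the same carbonyl carbon. Also open, going by these compounds, is whether exchanging oxetan-3-yl for oxan-4-yl would read the same way on a core carrying hydroxy rather than methoxy, as the core of compound 2 does.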